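Moving the chlorine in a second setting

A few compounds are considered here, and "the series" means these few. Any claim that something is new, unique, unknown or untested is made for them only; others in the source may bear on it.

Compound 1 `CC(C)c1ccc(-c2nc(SCc3cn(CC(=O)NC(=O)Nc4ccccn4)nn3)nc(Nc3ccc(Cl)cc3)c2C#N)cc1` was examined in a functional assay on MGC-803 cells (Homo sapiens) for inhibition, read by MTT assay, with a stated time of 72 h; on this read-out lower numbers stand for stronger inhibition and higher numbers for weaker inhibition. In this assay compound 1 gives > 64000 nM, which is a limit of the assay and not a number. Compound 2 `CC(C)c1ccc(-c2nc(SCc3cn(CC(=O)NC(=O)Nc4ccccn4)nn3)nc(Nc3cccc(Cl)c3)c2C#N)cc1` differs from compound 1 by 3-chlorophenyl in place of 4-chlorophenyl on a nitrogen on an aromatic ring. In this assay compound 2 gives > 64000 nM, again a limit of the assay rather than a number. The step that the two limits leave unreadable from compound 1 to compound 2 therefore cannot be read, since the limit of > 64000 nM in this assay, at which 2 of the 3 values shown sit, holds both values.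

Compound 3 `COc1cc(-c2nc(SCc3cn(CC(=O)NC(=O)Nc4ccccn4)nn3)nc(Nc3ccc(Cl)cc3)c2C#N)cc(OC)c1OC` has a different core from compound 1: 3,4,5-trimethoxyphenyl in place of 4-isopropylphenyl on an aromatic carbon. In this assay, going by the values given here, compound 3 gives 17500 nM, the only number among the three measured compounds. The step of an at least 3.6-fold lower number from compound 1 to compound 3 (0.56 log units; beyond the scatter) shows that this change of core brought the number down from the limit to a readable value.

Compound 4 `COc1cc(-c2nc(SCc3cn(CC(=O)NC(=O)Nc4ccccn4)nn3)nc(Nc3cccc(Cl)c3)c2C#N)cc(OC)c1OC` has not yet been measured. It differs from compound 3 by 3-chlorophenyl in place of 4-chlorophenyl on a nitrogen on an aromatic ring, the same change whose earlier step, a step that the two limits leave unreadable from compound 1 to compound 2, left no readable size. The surroundings of the exchanged group are the same in both pairs, so this is the same change made on the core of compound 3 rather than on the core of compound 1. With no readable size from that earlier step, the expectation for compound 4 rests on compound 3 and its value 17500 nM. The expected step is a 1.3-fold higher number from compound 3 to compound 4 (0.10 log units; within the scatter), a size that stays within the usual scatter. Compound 4 is accordingly estimated at 22000 nM, with a range from 8000 nM to 60000 nM.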

Compound 4, half-maximal inhibitory concentration: 15400 nM
Beside the measured number, compound 4's estimate is 1.4-fold (0.15 log units) above it; low and high end bracket the measured number.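

On the core of compound 3 in this assay, 3-chlorophenyl in place of 4-chlorophenyl gives a 1.1-fold lower number from compound 3 to compound 4 (0.06 log units; within the scatter), so on this core the two chlorophenyl groups on the nitrogen cannot be told apart. The same exchange on the core of compound 1 cannot be read, so nothing shows whether the result on the core of compound 3 carries over to that core or differs from it, since both compounds there sit at a limit of the assay: the limit of > 64000 nM in this assay, at which 2 of the 4 values shown sit. The other exchange, 3,4,5-trimethoxyphenyl in place of 4-isopropylphenyl, gives an at least 4.1-fold lower number from compound 2 to compound 4 (0.61 log units; beyond the scatter), and it runs the same way with either chlorophenyl group, though its size on the two cores cannot be compared: the same change on two cores in this assay, an at least 3.6-fold lower number (0.56 log units; beyond the scatter) from compound 1 to compound 3 and an at least 4.1-fold lower number (0.61 log units; beyond the scatter) from compound 2 to compound 4; the limit leaves it open whether they differ.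

The compounds shown leave open whether a fluorine or a methoxy group in place of the chlorine would separate from the chlorophenyl pair on the core of compound 3. They also leave open whether another group on the aromatic carbon, such as a single methoxy group or a carboxylic acid, would give readable values for both chlorophenyl groups, which is what a comparison between cores would need.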